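Replacing Chlorophenyl with Pyridinyl on a Fused Core

This account rests on a few compounds, and the source may have more. Where it says the series, first, only, none or still open, it means among the compounds named here.

Compound 1 `Cc1nc2c3ccccc3ccc2c2nc3c(ccc4ccccc43)c(-c3ccccc3Cl)c12` carries a 2-chlorophenyl group on a shared core. In a functional assay on HeLa cells (Homo sapiens) for cytotoxicity, read by MTT assay, with a stated time of 48 h (a higher number here means a weaker inhibitor, a lower number a stronger inhibitor), compound 1 gives > 80000 nM, which is a limit of the assay rather than a number. Compound 2 `Cc1nc2c3ccccc3ccc2c2nc3c(ccc4ccccc43)c(-c3ccccc3)c12`, with hydrogen in place of chloro on an aromatic carbon, gives > 80000 nM in this assay, again a limit. The step that the two limits leave unreadable from compound 1 to compound 2 therefore cannot be sized, as both values sit at the limit of > 80000 nM in this assay, at which 2 of the 3 values shown sit. For the measured compounds named here, compound 3 `Cc1nc2c3ccccc3ccc2c2nc3c(ccc4ccccc43)c(-c3cccc4ccccc34)c12`, with naphthalen-1-yl in place of 2-chlorophenyl, gives 14900 nM, the only number among the three, and the steps of an at least 5.3-fold lower number from compound 1 to compound 3 (0.72 log units; beyond the scatter) and an at least 5.3-fold lower number from compound 2 to compound 3 (0.72 log units; beyond the scatter) show that the two-ring group lowers the number beyond the scatter. Compound 4 `Cc1nc2c3ccccc3ccc2c2nc3c(ccc4ccccc43)c(-c3cccnc3)c12` is not yet measured; its change from compound 1 is pyridin-3-yl in place of 2-chlorophenyl on an aromatic carbon. A single six-membered ring enters, closer to the phenyl of compound 2 than to the naphthalen-1-yl of compound 3, so the unreadable step and the shared limit are the relevant precedents. Compound 4 is therefore expected to remain near the limit, with a step that the limit leaves unreadable from compound 1 to compound 4. The estimate for compound 4 is 100000 nM, within 30000 nM to 300000 nM.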

Compound 4, half-maximal inhibitory concentration: 3860 nM
Beside the measured number, compound 4's estimate is 26-fold (1.41 log units) above it, outside the stated range (below it).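

In this assay, the result shows that a large two-ring group is not needed at this position, since a single six-membered aromatic ring with one hetero atom does better than naphthalen-1-yl, with a 3.9-fold lower number from compound 3 to compound 4 (0.59 log units; beyond the scatter). Ring size alone therefore does not set the number: the all-carbon phenyl and pyridin-3-yl are both single rings, yet the change gives an at least 20-fold lower number from compound 2 to compound 4 (1.31 log units; beyond the scatter), and replacing 2-chlorophenyl gives an at least 20-fold lower number from compound 1 to compound 4 (1.31 log units; beyond the scatter). These last two steps give only a minimum size because compound 1 and compound 2 both stand at a limit of the assay: the limit of > 80000 nM in this assay, at which 2 of the 4 values shown sit.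

The compounds shown leave open whether the ring nitrogen must sit where it does in pyridin-3-yl, which pyridin-4-yl would test. They also leave open how an amine or a carboxylic acid on the ring would fare at this position.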